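The source may hold more compounds than are shown below. What is called first, only, known or untested is meant among the compounds shown, and "the series" means these compounds.

Compound 2 `Cc1cc(C)cc(SCc2ccc(/C=C/C(=O)Nc3ccccc3N)cc2)c1` holds the lower of the two numbers measured in a functional assay on A-375 cells (Homo sapiens) for inhibition, read by CCK-8 assay, with a stated time of 72 h, tested at 8 uM (a higher number here means more inhibition of growth at the concentration tested, a lower number less inhibition of growth), where compound 2 gives 2.49%. Compound 1 `Cc1ccc(SCc2ccc(/C=C/C(=O)Nc3ccccc3N)cc2)cc1` carries a different group on the sulfur and gives 31.2%; the step of a number 28.7 percentage points lower from compound 1 to compound 2 (beyond the scatter) shows that swapping 4-methylphenyl for 3,5-dimethylphenyl cost a modest amount of growth inhibition. Compound 3 `CC(C)(C)c1ccc(SCc2ccc(/C=C/C(=O)Nc3ccccc3N)cc2)cc1` has not been measured yet. It differs from compound 2 in one place: 4-(tert-butyl)phenyl in place of 3,5-dimethylphenyl on a sulfur. Within the data shown here, only one measured step bears on this change, the one from compound 1 to compound 2, and it compared two different phenyl groups on the same sulfur. A single step cannot say how 4-(tert-butyl)phenyl will behave, so the plausible range is wide, spanning roughly the values of compound 1 and compound 2. Compound 3 is estimated at 15%, with a range from 0% to 40%. That expectation means a step of a number 12.5 percentage points higher from compound 2 to compound 3 (beyond the scatter), a rise that may well fall within the scatter.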

Compound 3, percent growth inhibition at one concentration: 35.5%
Beside the measured number, compound 3's estimate is 20.5 percentage points below it, within the range that was stated.
By their numbers in this assay, from the lowest: compound 2; then compounds 1 and 3 (each within the scatter of the next).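

In this assay, the step of a number 33 percentage points higher from compound 2 to compound 3 (beyond the scatter) shows that a group on the sulfur with more heavy atoms does not by itself go with a low number: 4-(tert-butyl)phenyl has more than 3,5-dimethylphenyl, yet its number is far from that of compound 2. With the step of a number 4.3 percentage points higher from compound 1 to compound 3 (within the scatter), methyl and tert-butyl on that aromatic carbon cannot be told apart, so among these three compounds the 4-methylphenyl and 4-(tert-butyl)phenyl groups read alike and 3,5-dimethylphenyl alone stands apart. Nothing available explains why the 3,5-dimethylphenyl group gives the low number.

The compounds shown leave open whether a 3-methylphenyl group, with one methyl instead of two, would also give a low number. They also leave open how an amine or a carboxylic acid would behave in place of the tert-butyl group.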